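The compounds below may be only part of what the source reports. "The series", "measured", "known", "first", "only" and "open" are said of these compounds alone.

Measured so far:
- compound 1 `COc1ccc([C@@H]2CC(=O)c3c(O)cc(OCc4cn(CC5CC5)nn4)cc3O2)cc1O`: 11900 nM in a functional assay on RAW264.7 cells (Mus musculus) for inhibition, read by Griess assay, with stated times of 2 h and 24 h; on this read-out lower numbers stand for stronger inhibition and higher numbers for weaker inhibition
- compound 2 `COc1ccc([C@@H]2C/C(=N\O)c3c(O)cc(OCc4cn(Cc5ccccc5C)nn4)cc3O2)cc1O`: 18000 nM
- compound 3 `CCn1cc(COc2cc(O)c3c(c2)O[C@H](c2ccc(OC)c(O)c2)C/C3=N\O)nn1`: 3140 nM

Compound 1 holds the second highest of the three numbers; compound 2 sits within the scatter of it, while compound 3 shows a clearly lower number. Compound 4 `COc1ccc([C@@H]2CC(=O)c3c(O)cc(OCc4cn(C)nn4)cc3O2)cc1O` differs from compound 1 by hydrogen in place of cyclopropyl on a saturated chain carbon bound to an aromatic nitrogen. Among the measured compounds shown here, the one step that bears on this change is a 5.7-fold lower number from compound 2 to compound 3 (0.76 log units; beyond the scatter), where a substituent on that same chain carbon was likewise cut back to methyl, though on a different core. A smaller downward step is therefore expected for compound 4, a 1.8-fold lower number from compound 1 to compound 4 (0.26 log units; within the scatter), since only a small group leaves here. Compound 4 is estimated at 6500 nM, with a range from 2500 nM to 16000 nM.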

Compound 4, half-maximal inhibitory concentration: 15200 nM
Beside the measured number, compound 4's estimate is 2.3-fold (0.37 log units) below it; low and high end bracket the measured number.
By their numbers in this assay, from the lowest: compound 3; then compounds 1, 4 and 2 (each within the scatter of the next).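

In this assay, cutting cyclopropylmethyl back to methyl on the shared core gives a 1.3-fold higher number from compound 1 to compound 4 (0.11 log units; within the scatter), so this change at this position makes no readable difference. Among the compounds shown here, that differs from the only earlier step here, a 5.7-fold lower number from compound 2 to compound 3 (0.76 log units; beyond the scatter), where 2-methylphenyl left on a different core. Nothing available explains this contrast.

The compounds shown leave open whether an amine or a carboxylic acid on this chain carbon would move the number. They also leave open whether cyclopropylmethyl and methyl would read alike on the core of compound 2.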